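The source may report more compounds than this note shows. Statements on the series, on what has been measured and on what is new or still open speak of the compounds shown alone.

Measured so far:
compound 1 `CCCCN(CC)c1cc(C)nc2c1NC(=O)CN2c1ccc(C)cc1Br` gives 4.4 nM;
compound 2 `CCCCN(CC)c1cc(C)nc2c1NC(=O)CN2c1ccc(Cl)cc1C` gives 5.4 nM.

In an assay on HEK-293T cells for displacement of a labelled ligand from corticotropin-releasing factor receptor 1 (Homo sapiens), read by scintillation counting, with a stated time of 2 h (on this read-out lower numbers stand for stronger inhibition and higher numbers for weaker inhibition), compound 2 stands highest of the two numbers, but its nearest neighbour compound 1 sits within the scatter: a 1.2-fold higher number from compound 1 to compound 2 (0.09 log units; within the scatter). Compound 3 `CCCCN(CC)c1cc(C)nc2c1NC(=O)CN2c1ccc(Br)cc1CC` differs from compound 2 by 4-bromo-2-ethylphenyl in place of 4-chloro-2-methylphenyl on a nitrogen on an aromatic ring in a ring. For the measured compounds named here, the only measured step, a 1.2-fold higher number from compound 1 to compound 2 (0.09 log units; within the scatter), also exchanged one substituted phenyl for another on the same nitrogen and stayed within the scatter, so no step beyond the scatter is expected here. Compound 3 is therefore estimated at 5.5 nM. For compound 3 the expected range runs from 2.2 nM to 14 nM. This estimate means a step of a 1.0-fold higher number from compound 2 to compound 3 (0.01 log units; within the scatter).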

Compound 3, inhibition constant: 2.5 nM
For compound 3 the middle estimate is 2.2-fold (0.34 log units) above the measured one; low and high end bracket the measured number.
By their numbers in this assay, from the lowest: compounds 3, 1 and 2 (each within the scatter of the next, the first and the last beyond it).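

In this assay, the group on this nitrogen can shift the number beyond the scatter, which the earlier step did not show: 4-bromo-2-ethylphenyl in place of 4-chloro-2-methylphenyl gives a modest change (a 2.2-fold lower number from compound 2 to compound 3 (0.33 log units; beyond the scatter)). Measured against the 2-bromo-4-methylphenyl group, the same entering group stays within the scatter (a 1.8-fold lower number from compound 1 to compound 3 (0.25 log units; within the scatter)). No measurement at hand explains this step.

On these data alone, the halogen and the alkyl group changed together, so which one carries the step stays open. As far as these compounds go, how a methoxy group or a longer chain such as propyl would read here also stays open.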